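Acetyl for isopropyl on a bis-aziridinyl quinone core

A few compounds are considered here, and "the series" means these few. Any claim that something is new, unique, unknown or untested is made for them only; others in the source may bear on it.

Measured so far:
compound 1, `CCCC1=C(N2CC2)C(=O)C(C(COC(N)=O)OC)=C(N2CC2)C1=O` — 5.01
compound 2, `CC1=C(N2CC2)C(=O)C(C(C)C)=C(N2CC2)C1=O` — 4.96
compound 3, `CCC(COC(N)=O)C1=C(N2CC2)C(=O)C(C)=C(N2CC2)C1=O` — 6.03

Of the compounds shown here, three share one core and have been tested in a functional assay on L1210 cells (Mus musculus), with a stated time of 1 days; on this read-out lower numbers stand for lower potency and higher numbers for higher potency (the scale is a negative logarithm). Compound 2 stands lowest of the three numbers in this assay. Compound 1 sits nearest to it, a little higher but within the scatter of the method, so the two cannot be placed in order. Compound 3 lies furthest from compound 2 and its number is higher by more than the scatter allows; compound 3 is the only one of the three that stands clearly apart. None of the three differs from another in one place only, so no single-change step can be read from them.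

The next compound, compound 4, `CC(=O)C1=C(N2CC2)C(=O)C(C)=C(N2CC2)C1=O`, has not yet been measured in this assay. Set against compound 2 the change is this: acetyl in place of isopropyl on a double-bonded ring carbon.

For the measured compounds named here, with no measured step of this kind to lean on, the expectation for compound 4 rests on the spread of the three numbers. Compound 4 is expected to give 5.2 in this assay, within a range of 4.6 to 5.9. Compound 4 is thus estimated to move from compound 2 by a number 0.24 log units higher from compound 2 to compound 4 (within the scatter), a small rise that may not exceed the scatter.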

Compound 4, logarithm of the reciprocal of the active concentration, log(1/C): 3.94
Beside the measured number, compound 4's estimate is 1.26 log units above it; the measured number lies below the stated range.
By their numbers in this assay, from the lowest: compound 4; then compounds 2 and 1 (each within the scatter of the next); then compound 3.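

Acetyl in place of isopropyl on a double-bonded ring carbon, with the rest of the shared core unchanged, gives in this assay a number 1.02 log units lower from compound 2 to compound 4 (beyond the scatter) as the first single-change step in this set, and it is a large one. The leaving and entering groups carry the same count of heavy atoms, so at this position that count alone does not hold the number; what the exchange brings is an oxygen for a carbon, a double bond outside the ring and a hydrogen-bond acceptor. Nothing measured on these compounds bears on why the number falls.

Whether the fall belongs to acetyl in particular remains open, since the compounds shown place neither an amine, a carboxylic acid nor a longer chain of carbon on this same double-bonded ring carbon against isopropyl. For the compounds shown here, also open is what sets compound 3 apart from the others, as it differs from each of them in more than one place and so gives no single-change step.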